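Methoxy in Place of Methoxycarbonyl: Expected Cytotoxicity

The compounds below may be only part of what the source reports. "The series", "measured", "known", "first", "only" and "open" are said of these compounds alone.

Compound 1 `Cc1cc(NC(=O)Nc2ccccc2OC(F)(F)F)c2ccccc2n1` gives > 25000 nM in an ADME assay on HepG2 cells (Homo sapiens) for cytotoxicity, with a stated time of 72 h (a lower number here means that less compound is needed, a higher number that more compound is needed for the effect), a limit of the assay.
Compound 2 `Cc1cc(NC(=O)Nc2cccc(C(N)=O)c2)c2ccccc2n1` gives > 25000 nM in this assay, also a limit.
Compound 3 `COC(=O)c1ccc(NC(=O)Nc2cc(C)nc3ccccc23)cc1` gives 20000 nM in this assay.

Within the data shown here, compound 3 thus stands as the only compound with a measured number; the other two sit at the limit of > 25000 nM in this assay, at which 2 of the 3 values shown sit. Compound 4 `COc1ccc(NC(=O)Nc2cc(C)nc3ccccc23)cc1` has not yet been measured. It differs from compound 3 in one place: methoxy in place of methoxycarbonyl on an aromatic carbon. Among the measured compounds shown here, no step between measured compounds is available, so the size of this change cannot be read from the data. Since compound 3 gives 20000 nM, the step of a 1.3-fold higher number from compound 3 to compound 4 (0.10 log units; within the scatter) is expected to stay within the scatter, in no particular direction. Compound 4 is therefore estimated at 25000 nM, between 12000 nM and 50000 nM, with a fair chance that the assay reports only a limit.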

Compound 4, half-maximal effective concentration: > 25000 nM
Compound 4: no number, only a limit; the forecaster's own chance of this, stated with the estimate: 50%; the middle value sits exactly at the limit.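

Methoxy in place of methoxycarbonyl on an aromatic carbon, para to a large group, gives in this assay an at least 1.2-fold higher number from compound 3 to compound 4 (0.09 log units; that floor lies within the scatter). Among these compounds, this is the first step that can be read at this position, but it is only a floor. Its true size stays unknown because compound 4 joins the compounds reported only as a limit: the limit of > 25000 nM in this assay, at which 3 of the 4 values shown sit.

Among the compounds shown here, compound 3 remains the only compound with a number, so it is open how far the change really reaches. From the compounds shown here alone, it is also open whether an amine or a carboxylic acid at this position would give a measured number.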